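The source may hold more compounds than are shown below. What is called first, only, known or untested is meant among the compounds shown, and "the series" means these compounds.

Measured so far in an ADME assay on liver for metabolic stability, with Liver microsome (Homo sapiens) as the target, read by LC-MS, using microsomes; on this read-out higher numbers stand for fast clearance and lower numbers for slow clearance:

Compound 1 `CC(C)(C)[C@@H](O)C(=O)N1[C@@H]2C[C@@H]2C[C@H]1C(=O)NCc1cc(Cl)ccc1-n1cnnn1` gives 54 mL.min-1.g-1.
Compound 2 `O=C(NCc1cc(Cl)ccc1-n1cnnn1)[C@@H]1[C@H]2C[C@H]2CN1C(=O)[C@H](O)CC1CC1` gives only a limit of the assay, < 14 mL.min-1.g-1.
Compound 3 `O=C(NCc1cc(Cl)ccc1-n1cnnn1)[C@@H]1C[C@@H]2C[C@@H]2N1C(=O)[C@H](O)Cc1ccccn1` gives 17 mL.min-1.g-1.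

Among the two actual numbers, compound 3 stands at the lower one. The nearest number is that of compound 1, which is higher than compound 3 by a gap that lies beyond the usual scatter of repeated measurements. Compound 2 adds no number to compare with, since its result is a limit only.

Compound 4 `COC(C)(C)[C@@H](O)C(=O)N1[C@H](C(=O)NCc2cc(Cl)ccc2-n2cnnn2)C[C@@H]2C[C@@H]21` has not yet been measured in this assay. It differs from compound 3 in one place: 1-methoxy-1-methylethyl in place of (pyridin-2-yl)methyl on a saturated chain carbon bound to a carbonyl carbon and an oxygen on a saturated carbon. Among the compounds with values here, no measured pair of compounds shares this change, so no step of known size can be leaned on.

What can be said rests on the three results above. Compound 3 sits low, compound 1 sits clearly higher, and compound 2 sits at the limit. The change removes the ring and puts a smaller, non-ring group in its place. For compound 4 the expectation is a step of a 1.6-fold higher number from compound 3 to compound 4 (0.22 log units; within the scatter) upward from compound 3, of a size that may or may not exceed the scatter. Compound 4 is thus estimated at 28 mL.min-1.g-1, within a range from 14 mL.min-1.g-1 to 60 mL.min-1.g-1.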

Compound 4, intrinsic clearance in microsomes: 40 mL.min-1.g-1
Compound 4: middle estimate off by 1.4-fold (0.15 log units), on the low side; the measured number falls inside the stated range.
By their numbers in this assay, from the lowest: compound 3; then compounds 4 and 1 (each within the scatter of the next). At a limit, below all of these: compound 2.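

In this assay, putting 1-methoxy-1-methylethyl in place of (pyridin-2-yl)methyl, on a saturated chain carbon bound to a carbonyl carbon and an oxygen on a saturated carbon, gives a 2.4-fold higher number from compound 3 to compound 4 (0.37 log units; beyond the scatter). This is the only pair shown that differs in one place, so it is the first direct sign that the group at this place can shift the clearance read-out by more than the usual scatter, something the earlier compounds, which differ in more than one place, could not show. The two groups have the same counts of hydrogen-bond donors and acceptors but differ in size, in having a ring and in their hetero atom, and nothing measured here says which of these differences lies behind the step.

As far as these compounds go, a single swap changes all three features at once, so their separate shares remain open. Phenylmethyl at this place would keep a six-membered aromatic ring without its nitrogen, and 2-methoxyethyl would keep the ether oxygen in an unbranched chain, so each would help to show which feature goes with the higher number.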